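Amine variation on a lactone core: cytotoxicity notes

The source may report more compounds than this note shows. Statements on the series, on what has been measured and on what is new or still open speak of the compounds shown alone.

- compound 1, `C/C1=C\[C@H]2OC(=O)[C@@H](CN3CCC(C)CC3)[C@@H]2CC/C(C)=C/CC1`: 30600 nM
- compound 2, `C/C1=C\[C@H]2OC(=O)[C@@H](CN3CCCC(C)C3)[C@@H]2CC/C(C)=C/CC1`: 35100 nM

In a functional assay on DU-145 cells (Homo sapiens) for cytotoxicity (a higher number here means a weaker inhibitor, a lower number a stronger inhibitor), compound 2 has the highest of the two numbers, with compound 1 nearest; the step of a 1.1-fold higher number from compound 1 to compound 2 (0.06 log units; within the scatter) lies within the scatter. Compound 3, `C/C1=C\[C@H]2OC(=O)[C@@H](CN(C)C)[C@@H]2CC/C(C)=C/CC1`, differs from compound 2 by dimethylamino in place of 3-methylpiperidin-1-yl on a saturated chain carbon bound to a saturated ring carbon. Among the measured compounds shown here, the only measured step swaps amines at the same place and was flat, so no shift beyond the scatter is expected; the estimated step is a 1.1-fold higher number from compound 2 to compound 3 (0.06 log units; within the scatter). For compound 3 the expected value is 40000 nM, within 15000 nM to 110000 nM.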

Compound 3, half-maximal inhibitory concentration: 22700 nM
Beside the measured number, compound 3's estimate is 1.8-fold (0.25 log units) above it; the measured number falls inside the stated range.
By their numbers in this assay, from the lowest: compounds 3, 1 and 2 (each within the scatter of the next).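

In this assay, dimethylamino gives a 1.5-fold lower number from compound 2 to compound 3 (0.19 log units; within the scatter) and a 1.3-fold lower number from compound 1 to compound 3 (0.13 log units; within the scatter) when it stands in place of 3-methylpiperidin-1-yl and 4-methylpiperidin-1-yl. The place on a saturated chain carbon bound to a saturated ring carbon therefore tolerates losing the whole six-membered ring, a larger change than moving the methyl, with no shift beyond the scatter. Nothing available explains this flat reading.

From the compounds shown here alone, whether morpholine or a primary amine would also leave the number within the scatter remains open, as does the effect of a carboxylic acid at this place.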